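Shortening the Selenium Chain on Two Related Cores

The source may hold more compounds than are shown below. What is called first, only, known or untested is meant among the compounds shown, and "the series" means these compounds.

Compound 1 `CCCCC[Se]c1nc(NCc2ccccc2)c2ccccc2n1` and compound 3 `C[Se]c1nc(NCc2ccccc2)c2ccccc2n1` share one core and differ in a single place: hydrogen in place of butyl on a saturated chain carbon bound to a selenium atom. In a functional assay on HT-29 cells (Homo sapiens) for cytotoxicity, read by MTT assay, with a stated time of 72 h (a higher number here means a weaker inhibitor of growth, a lower number a stronger inhibitor of growth), compound 1 gives only a limit of the assay, > 100000 nM. Compound 3 gives 81000 nM. This change therefore gives an at least 1.2-fold lower number from compound 1 to compound 3 (0.09 log units; that floor lies within the scatter), a floor that rests on (the limit of > 100000 nM in this assay, at which 1 of the 3 values shown sits). Compound 2 `CCCCC[Se]c1nc(N)c2cccnc2n1` stands on another core; the difference between the two cores is not broken down here. In this assay compound 2 gives 20000 nM. Compound 4 `C[Se]c1nc(N)c2cccnc2n1` has not yet been measured and differs from compound 2 by the same change: hydrogen in place of butyl on a saturated chain carbon bound to a selenium atom. Because the measured step of an at least 1.2-fold lower number from compound 1 to compound 3 (0.09 log units; that floor lies within the scatter) stays within the usual scatter, the expected step for compound 4 is a 1.3-fold lower number from compound 2 to compound 4 (0.12 log units; within the scatter). Compound 4 is therefore estimated at 15000 nM, most likely between 5000 nM and 45000 nM.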

Compound 4, concentration for total growth inhibition: 77300 nM
Compound 4: middle estimate off by 5.2-fold (0.71 log units), on the low side; measured number above the stated range.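

On the core of compound 2, hydrogen in place of butyl on a saturated chain carbon bound to a selenium atom (pentyl to methyl) gives a 3.9-fold higher number from compound 2 to compound 4 (0.59 log units; beyond the scatter) in this assay. The step seen on one core therefore does not carry over to the other in this series: the same change on two cores in this assay, an at least 1.2-fold lower number (0.09 log units; that floor lies within the scatter) from compound 1 to compound 3 and a 3.9-fold higher number (0.59 log units; beyond the scatter) from compound 2 to compound 4, at least 4.7-fold (0.67 log units) apart, beyond the scatter of two such steps The true size of the step on the first core remains unknown and the data do not show why the cores differ, as compound 1 gives only a limit of the assay: the limit of > 100000 nM in this assay, at which 1 of the 4 values shown sits.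

From the compounds shown here alone, whether an ethyl or propyl chain on the selenium would follow either step remains open. So does the effect of a longer chain, such as octyl, on each core.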